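Varying the indole nitrogen substituent in 5-alpha-reductase inhibitors

The source may report more compounds than this note shows. Statements on the series, on what has been measured and on what is new or still open speak of the compounds shown alone.

Measured compounds:
compound 1 `C/C(=C\C(=O)Nc1ccccc1OCCCC(=O)O)c1ccc2c(ccn2C)c1`: 780 nM
compound 2 `C/C(=C\C(=O)Nc1ccccc1OCCCC(=O)O)c1ccc2c(ccn2CC(C)C)c1`: 160 nM
compound 3 `CCC(C)n1ccc2cc(/C(C)=C/C(=O)Nc3ccccc3OCCCC(=O)O)ccc21`: 67 nM

In an assay on Prostate gland for inhibition of steroid 5-alpha-reductase (Rattus norvegicus) (a higher number here means a weaker inhibitor, a lower number a stronger inhibitor), compound 1 gives 780 nM, compound 2 gives 160 nM and compound 3 gives 67 nM. Compound 2 therefore holds the second highest of the three numbers: its nearest neighbour is compound 3, below it, and the furthest is compound 1, above it.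

The step from compound 2 to compound 4 `C/C(=C\C(=O)Nc1ccccc1OCCCC(=O)O)c1ccc2c(ccn2Cc2ccc(F)cc2)c1` changes the substituent on a saturated chain carbon bound to an aromatic nitrogen (4-fluorophenyl in place of isopropyl on a saturated chain carbon bound to an aromatic nitrogen).

For the measured compounds named here, two measured steps bear on this change. The step of a 4.9-fold lower number from compound 1 to compound 2 (0.69 log units; beyond the scatter) shows that enlarging the group on the aromatic nitrogen lowers the number, and the step of a 2.4-fold lower number from compound 2 to compound 3 (0.38 log units; beyond the scatter) shows that a further change of the same group among saturated chains lowers it again. Going by the values given here, the 4-fluorophenyl group that enters is larger than the isopropyl that leaves and brings a six-membered aromatic ring of carbon only, which none of the measured compounds carries, so the direction is taken from these steps while the size remains uncertain. A modest lowering of the number in this assay is expected, on the order of a 2.0-fold lower number from compound 2 to compound 4 (0.30 log units; within the scatter).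

Compound 4 is thus estimated at 80 nM, within a range from 25 nM to 300 nM.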

Compound 4, half-maximal inhibitory concentration: 97 nM
Compound 4: middle estimate off by 1.2-fold (0.08 log units), on the low side; the measured number falls inside the stated range.
By their numbers in this assay, from the lowest: compounds 3, 4 and 2 (each within the scatter of the next, the first and the last beyond it); then compound 1.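

In this assay, an aromatic ring is accepted on the saturated chain carbon bound to an aromatic nitrogen: with 4-fluorobenzyl in place of the methyl group, the result is an 8.0-fold lower number from compound 1 to compound 4 (0.91 log units; beyond the scatter) and so keeps a gain of the kind the saturated chains gave. The larger group with its six-membered aromatic ring cannot be separated from the saturated chains, as a 1.6-fold lower number from compound 2 to compound 4 (0.22 log units; within the scatter) and a 1.4-fold higher number from compound 3 to compound 4 (0.16 log units; within the scatter) both lie within the scatter, so compound 4 takes no order relative to compound 2 or compound 3, although those two differ beyond the scatter. Nothing is available to explain why these groups give the numbers they do.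

Open, from the compounds shown here alone, is how a plain benzyl group would compare with 4-fluorobenzyl on the aromatic nitrogen, and whether a longer chain ending in an amine or a carboxylic acid would be accepted there. Equally open, going by these compounds, is how a phenyl group placed directly on the aromatic nitrogen would compare with 4-fluorobenzyl.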